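Working notes: from compound 3 to compound 4

A few compounds are considered here, and "the series" means these few. Any claim that something is new, unique, unknown or untested is made for them only; others in the source may bear on it.

- compound 1 `FC(F)(F)Oc1ccc(-c2ccc(-c3ccc(-c4nc5ccccc5[nH]4)cc3)cc2)cc1`: 38400 nM
- compound 2 `Oc1cccc2[nH]c(-c3ccc(-c4ccc(-c5ccc(F)cc5)cc4)cc3)nc12`: 9100 nM
- compound 3 `Oc1cccc2[nH]c(-c3ccc(-c4ccc(-c5ccc(C(F)(F)F)cc5)cc4)cc3)nc12`: 3720 nM

In a functional assay on SiHa cells (Homo sapiens) for inhibition, read by sulforhodamine B assay (on this read-out lower numbers stand for stronger inhibition of growth and higher numbers for weaker inhibition of growth), compound 3 has the lowest number of the three compounds measured, and its gaps to compound 2 and compound 1 are both beyond the scatter. Compound 4 `Oc1cccc2[nH]c(-c3ccc(-c4ccc(-c5ccc(OC(F)(F)F)cc5)cc4)cc3)nc12` carries trifluoromethoxy in place of trifluoromethyl on an aromatic carbon, para to a large group: trifluoromethoxy in place of trifluoromethyl on an aromatic carbon.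

Within the data shown here, only one measured step bears on this change. It is a substituent exchange on an aromatic carbon, trifluoromethyl in place of fluoro, and it gave a 2.4-fold lower number from compound 2 to compound 3 (0.39 log units; beyond the scatter), a modest effect. Among the measured compounds shown here, compound 1 differs from compound 3 in more than one place, so it offers no clean step. The data contain no direct measurement of this exchange. A small change in this assay, not beyond the scatter and without a firm direction, is therefore expected, with an estimated 1.1-fold higher number from compound 3 to compound 4 (0.03 log units; within the scatter). For compound 4 the estimated value is 4000 nM, with an expected range of 1800 nM to 9000 nM.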

Compound 4, concentration for 50% growth inhibition: 8410 nM
Compound 4: middle estimate off by 2.1-fold (0.32 log units), on the low side; the range from low to high includes it.
By their numbers in this assay, from the lowest: compound 3; then compounds 4 and 2 (each within the scatter of the next); then compound 1.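

At the position para to a large group, in this assay, trifluoromethoxy and trifluoromethyl are not interchangeable: the exchange gives a 2.3-fold higher number from compound 3 to compound 4 (0.35 log units; beyond the scatter). Trifluoromethoxy in place of fluoro gives a 1.1-fold lower number from compound 2 to compound 4 (0.03 log units; within the scatter), so of the three groups tried here, only trifluoromethyl stands apart from the other two, and the earlier gain over fluoro does not carry over to the group with the added oxygen. Among these compounds, compound 4 also gives the first clean reading of the hydroxy on an aromatic carbon of the core, with trifluoromethoxy held constant: a 4.6-fold lower number from compound 1 to compound 4 (0.66 log units; beyond the scatter).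

No measurement at hand accounts for any of these differences. Still open, going by these compounds, are how an amine, a carboxylic acid or a longer alkoxy chain would behave at this position, and whether the hydroxy step holds with other groups there.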